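Carbamoyl on the shared core: what to expect

This account rests on a few compounds, and the source may have more. Where it says the series, first, only, none or still open, it means among the compounds named here.

In a functional assay on KB cells (Homo sapiens) for inhibition (on this read-out lower numbers stand for stronger inhibition and higher numbers for weaker inhibition), compound 2 `N#C/N=C(\N)c1cn([C@@H]2O[C@H](CO)[C@@H](O)[C@H]2O)c2nnnc(N)c12` gives 5000 nM. That is the second highest of three numbers, since compound 1 `N/C(=N\O)c1cn([C@@H]2O[C@H](CO)[C@@H](O)[C@H]2O)c2nnnc(N)c12` gives 1500 nM and compound 3 `Cc1ccc(C(=O)OC[C@H]2O[C@@H](n3cc(C(N)=O)c(C(N)=O)c3N)C[C@@H]2OC(=O)c2ccc(C)cc2)cc1` gives 100000 nM. For the measured compounds named here, compound 3 has a different structure and no measured step linking it to the others, so it offers little guidance here.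

The next compound, compound 4 `NC(=O)c1cn([C@@H]2O[C@H](CO)[C@@H](O)[C@H]2O)c2nnnc(N)c12`, differs from compound 2 as follows: a group of 3 heavy atoms (1 carbon, 1 nitrogen, 1 oxygen; no ring) in place of a group of 5 heavy atoms (2 carbon, 3 nitrogen; no ring), on an aromatic carbon. The carbamoyl group sits on an aromatic carbon of a five-membered aromatic ring.

Going by the values given here, only one measured step bears on this change: a 3.3-fold higher number from compound 1 to compound 2 (0.52 log units; beyond the scatter). That step alters the same group that carbamoyl would replace whole. Among the compounds with values here, that modest step lies beyond the scatter, so changes in this group can shift the number, but no measured compound on this core carries carbamoyl. A modest move towards stronger inhibition is therefore only a tentative expectation. The expected step is a 4.2-fold lower number from compound 2 to compound 4 (0.62 log units; beyond the scatter). Compound 4 is estimated at 1200 nM, with an expected range of 200 nM to 6000 nM.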

Compound 4, half-maximal inhibitory concentration: 80 nM
The estimate for compound 4 lay 15-fold (1.18 log units) above the measured number; the whole stated range lies above it.
By their numbers in this assay, from the lowest: compound 4; then compound 1; then compound 2; then compound 3.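

In this assay the group on this aromatic carbon of the five-membered ring matters far more than the modest earlier step suggested: carbamoyl gives a 63-fold lower number from compound 2 to compound 4 (1.80 log units; beyond the scatter) and also a 19-fold lower number from compound 1 to compound 4 (1.27 log units; beyond the scatter) on the shared core. Among these three compounds, the number falls as the group holds fewer heavy atoms, although three compounds are too few to establish a rule. Nothing measured here explains why the steps are so large.

On these data alone, it remains open whether carbamoyl itself matters or any similarly short group would do, and a carboxylic acid or a nitrile at this position would help separate those two possibilities. Compound 3 also carries carbamoyl groups, but its different structure and lack of a linking step leave it unable to settle the question.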